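Swapping a tert-butyl ester for a benzyl ester

This account rests on a few compounds, and the source may have more. Where it says the series, first, only, none or still open, it means among the compounds named here.

Measured compounds:
compound 1 `CC1=C(C(=O)OC(C)(C)C)C(c2ccsc2)NC(=S)N1` gives 26%
compound 2 `CC1=C(C(=O)OCc2ccccc2)C(c2ccsc2)NC(=S)N1` gives 10%
compound 3 `CC1=C(C(=O)OC(C)(C)C)C(c2cccs2)NC(=O)N1C` gives 24%

All three were tested in an assay on membranes from HEK293 cells for displacement of a labelled ligand from adenosine receptor A2b (Homo sapiens), read by scintillation counting, with a stated time of 30 min, tested at 1 uM; on this read-out lower numbers stand for less inhibition and higher numbers for more inhibition at the one concentration tested (going by the name of the read-out). Compound 1 and compound 2 share one core and differ in a single place:

benzyl in place of tert-butyl on an oxygen next to a carbonyl group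

That change gave a number 16 percentage points lower from compound 1 to compound 2 (beyond the scatter). Compound 3 is built on a different core; the difference between the two cores is not broken down here. In this assay compound 3 gives 24%, which lies within the usual scatter of the number for compound 1, so no order between these two can be claimed, while compound 2 sits beyond the scatter below compound 3.

Compound 4 `CC1=C(C(=O)OCc2ccccc2)C(c2cccs2)NC(=O)N1C` has not been measured. It differs from compound 3 in exactly one place:

benzyl in place of tert-butyl on an oxygen next to a carbonyl group

The place is the same word for word as in the pair of compound 1 and compound 2, so this is the same change, made for the second time among these compounds. Within the data shown here, the only guide to its effect is that single earlier step, and the expectation rests on it: because compound 1 to compound 2 showed a number 16 percentage points lower from compound 1 to compound 2 (beyond the scatter), a step of about the same size and direction is expected here, namely a number 16 percentage points lower from compound 3 to compound 4 (beyond the scatter). Among the measured compounds shown here, with only one prior example, the range is kept wide. Compound 4 is therefore estimated at 8%, with a likely span from -6% to 22% in this assay.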

Compound 4, a percentage reported as inhibition, at one concentration (the size of the read-out at that concentration, not a potency): 50%
The estimate for compound 4 lay 42 percentage points below the measured number; measured number outside the range, above it.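

Putting benzyl in place of tert-butyl on the core of compound 3 gave a number 26 percentage points higher from compound 3 to compound 4 (beyond the scatter) in this assay, so the swap that lowered the number on one core raised it on the other. Set side by side, the two results show that this change cannot be carried from one core to the other as a fixed step, not even in its direction: the same change on two cores in this assay, a number 16 percentage points lower (beyond the scatter) from compound 1 to compound 2 and a number 26 percentage points higher (beyond the scatter) from compound 3 to compound 4, 42 percentage points apart, beyond the scatter of two such steps. Among these compounds, what this does not show is which part of the cores turns the step around, since they are not broken down here, and with only one pair on each core, no general rule for either core can be drawn from these steps.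

The compounds shown leave open how a methyl ester, a longer chain on the same oxygen, or a carboxylic acid or an amide in place of the ester would behave on each of the two cores. They also leave open how these compounds compare in potency, since each number comes from a single concentration and reports only the size of the read-out there.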